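Methoxy to Trifluoromethyl at a Second Place on the Ring

This account rests on a few compounds, and the source may have more. Where it says the series, first, only, none or still open, it means among the compounds named here.

Three measured compounds share one core, shown beside each structure. Compound 1 `COc1ccc(C(=O)N(CCN2CCC(OCC(=O)O)CC2)c2ccc(Cl)cc2)cc1` carries a (4-methoxyphenyl)carbonyl group on the amide-type nitrogen; in a functional assay on a cell-free system (Platelet, plasma, Homo sapiens) for inhibition (on this read-out lower numbers stand for stronger inhibition and higher numbers for weaker inhibition), compound 1 gives 3100 nM. Compound 2 `O=C(O)COC1CCN(CCN(C(=O)c2ccc(C(F)(F)F)cc2)c2ccc(Cl)cc2)CC1` differs from compound 1 by trifluoromethyl in place of methoxy on an aromatic carbon. For compound 2 this assay reports only a limit, > 10000 nM. The step of an at least 3.2-fold higher number from compound 1 to compound 2 (0.50 log units; beyond the scatter) therefore rests on (the limit of > 10000 nM in this assay, at which 1 of the 3 values shown sits). Compound 3 `COc1cccc(C(=O)N(CCN2CCC(OCC(=O)O)CC2)c2ccc(Cl)cc2)c1` has the same atoms as compound 1, joined differently: 3-methoxyphenyl in place of 4-methoxyphenyl on a carbonyl carbon. In this assay compound 3 gives 74 nM, so that the step of a 42-fold lower number from compound 1 to compound 3 (1.62 log units; beyond the scatter) is the largest change among the measured compounds, and from compound 2 the step is an at least 130-fold lower number from compound 2 to compound 3 (2.13 log units; beyond the scatter).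

Compound 4 `O=C(O)COC1CCN(CCN(C(=O)c2cccc(C(F)(F)F)c2)c2ccc(Cl)cc2)CC1` remains to be measured. It differs from compound 3 by trifluoromethyl in place of methoxy on an aromatic carbon. This is the same kind of change as that from compound 1 to compound 2, not the same change: there the group sits para to a large group, here meta to a large group. Because an at least 3.2-fold higher number from compound 1 to compound 2 (0.50 log units; beyond the scatter) moved toward weaker inhibition, compound 4 is expected to follow the same direction from compound 3, with an estimated step of a 5.4-fold higher number from compound 3 to compound 4 (0.73 log units; beyond the scatter). The different place around the substituent leaves the size uncertain. Compound 4 is thus estimated at 400 nM in this assay, with an expected range from 100 nM to 3000 nM.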

Compound 4, half-maximal inhibitory concentration: > 10000 nM
Compound 4 was reported as a limit (the forecaster's own chance of this, stated with the estimate: 8%); middle value at least 25-fold (1.39 log units) away from the limit.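

In this assay compound 4 gives > 10000 nM, which is a limit of the assay and not a number. Trifluoromethyl in place of methoxy therefore moved the read-out toward weaker inhibition on both cores, with an at least 130-fold higher number from compound 3 to compound 4 (2.13 log units; beyond the scatter) here, and the direction of the change carried over, but its size cannot be said to have carried over: the same change on two cores in this assay, an at least 3.2-fold higher number (0.50 log units; beyond the scatter) from compound 1 to compound 2 and an at least 130-fold higher number (2.13 log units; beyond the scatter) from compound 3 to compound 4; the limit leaves it open whether they differ Compound 4 also stands with an at least 3.2-fold higher number from compound 1 to compound 4 (0.50 log units; beyond the scatter), while the step between the two trifluoromethyl compounds cannot be read, so the series shows no ranking of the two trifluoromethyl placements, and the reach of the comparison ends at this shared ceiling: the limit of > 10000 nM in this assay, at which 2 of the 4 values shown sit.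

The compounds shown leave open whether another group in the place of the methoxy of compound 3, such as ethoxy, hydroxy or a chlorine atom, would keep its inhibition or fall to the limit as compound 4 does. They also leave open whether the same change would run the same way on a core that carries a tetrazole in place of the carboxylic acid.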